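The source may hold more compounds than are shown below. What is called first, only, known or untested is meant among the compounds shown, and "the series" means these compounds.

Compound 1 `COc1ccc(-c2cc(NNC(=O)Nc3cc(Cl)nc(Cl)c3)nc3c2cnn3C)cc1`: 520 nM
Compound 2 `Cn1ncc2c(-c3ccccc3)cc(NNC(=O)Nc3cc(Cl)nc(Cl)c3)nc21`: 1020 nM
Compound 3 `CC(C)c1cc(NNC(=O)Nc2cc(Cl)nc(Cl)c2)nc2c1cnn2C`: 780 nM

In an assay on isolated protein for binding affinity to sphingosine 1-phosphate receptor 2 (Homo sapiens), read by surface plasmon resonance (a higher number here means weaker binding, a lower number tighter binding), compound 1 gives 520 nM, the lowest of the three numbers, yet its neighbours sit within the scatter: a 2.0-fold higher number from compound 1 to compound 2 (0.29 log units; within the scatter) and a 1.5-fold higher number from compound 1 to compound 3 (0.18 log units; within the scatter). Between the other two, a 1.3-fold lower number from compound 2 to compound 3 (0.12 log units; within the scatter). All three measured steps change the group on the core's other side, and all are within the scatter, so this series gives no sign that such changes move the number.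

Compound 4 `CCCCOc1cc(NC(=O)NNc2cc(-c3ccc(OC)cc3)c3cnn(C)c3n2)cc(Cl)n1` differs from compound 1 by a change on the six-membered aromatic ring with one nitrogen: butoxy in place of chloro on an aromatic carbon. Going by the values given here, no measured step touches that ring, so there is nothing to set the size of this step directly; the only guidance is that every change measured so far stayed within the scatter. The expected step is therefore small, a 1.2-fold higher number from compound 1 to compound 4 (0.06 log units; within the scatter), with the direction open. Compound 4 is estimated at 600 nM, within a range from 150 nM to 2400 nM that allows a real shift either way.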

Compound 4, dissociation constant: 4150 nM
The estimate for compound 4 lay 6.9-fold (0.84 log units) below the measured number; the measured number lies above the stated range.
By their numbers in this assay, from the lowest: compounds 1, 3 and 2 (each within the scatter of the next); then compound 4.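

In this assay replacing the chloro with butoxy gives an 8.0-fold higher number from compound 1 to compound 4 (0.90 log units; beyond the scatter) and is the only step shown that lies beyond the scatter. The number at this position, next to the ring nitrogen, therefore responds to the group placed there, whereas the changes on the other side of the core stayed within the scatter; here, five heavy atoms in place of one go with weaker binding. No measurement shown explains the weaker binding.

This single step cannot separate losing the chloro from gaining the butoxy chain, or the chain's length from its oxygen. From the compounds shown here alone, whether a shorter ethoxy group or an amine in the same place would keep the number close to that of compound 1 remains open.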